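This account rests on a few compounds, and the source may have more. Where it says the series, first, only, none or still open, it means among the compounds named here.

Compound 1 `O=S1(=O)C=Cc2ccc(Nc3ccc(C(F)(F)F)cc3)cc21` and compound 2 `O=S1(=O)C=Cc2ccc(Nc3ccc(Cl)cc3)cc21` share one core and differ only in a single group on the outer ring. In a functional assay on A549 cells (Homo sapiens) for antiproliferative activity, read by MTT assay, with a stated time of 72 h (on this read-out lower numbers stand for stronger inhibition and higher numbers for weaker inhibition), compound 1 gives 1140 nM, while compound 2 gives 2300 nM. The change between them, (chloro in place of trifluoromethyl on an aromatic carbon), produced a 2.0-fold higher number from compound 1 to compound 2 (0.30 log units; within the scatter). Compound 3 `O=S1(=O)C=Cc2cccc(Nc3ccc(C(F)(F)F)cc3)c21` is built from the same atoms as compound 1, joined differently, so its core is a rearranged version of that of compound 1; the difference between the two cores is not broken down here. In this assay compound 3 gives 2440 nM. Compound 4 `O=S1(=O)C=Cc2cccc(Nc3ccc(Cl)cc3)c21` has not yet been measured. It differs from compound 3 by chloro in place of trifluoromethyl on an aromatic carbon, which is the same change as that made from compound 1 to compound 2, at the same place on the outer ring. The same change is expected to give a 2.0-fold higher number from compound 3 to compound 4 (0.29 log units; within the scatter), because on the other core it gave a 2.0-fold higher number from compound 1 to compound 2 (0.30 log units; within the scatter), and the rearranged core offers no reason to expect anything different. The estimate for compound 4 in this assay is therefore 4800 nM, with a likely range from 2400 nM to 9600 nM.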

Compound 4, half-maximal inhibitory concentration: 1040 nM
Beside the measured number, compound 4's estimate is 4.6-fold (0.66 log units) above it, and the stated range ends above it.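

In this assay, putting chloro in place of trifluoromethyl on the rearranged core gave a 2.3-fold lower number from compound 3 to compound 4 (0.37 log units; beyond the scatter), so the change did not behave as it had on the core of compound 1. Set side by side, the two results differ by more than measurement scatter would explain, which means that the effect of this change depends on the core it is made on: the same change on two cores in this assay, a 2.0-fold higher number (0.30 log units; within the scatter) from compound 1 to compound 2 and a 2.3-fold lower number (0.37 log units; beyond the scatter) from compound 3 to compound 4, 4.7-fold (0.68 log units) apart, beyond the scatter of two such steps. This rests on just one pair of compounds per core, and the step on the core of compound 1 is itself within the scatter, so the data show that the change cannot be carried safely from one core to the other, but not why the cores differ or whether other changes would also fail to carry over.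

The compounds shown have only trifluoromethyl or chloro on the outer ring. As far as these compounds go, how a methoxy group, a nitrile, an amine or a carboxylic acid at that place would read on either core remains open, as does whether those groups would also differ between the two cores.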